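The source may hold more compounds than are shown below. What is called first, only, known or untested is meant among the compounds shown, and "the series" means these compounds.

Three compounds of the series have numbers in an assay on HEK293 cells for displacement of a labelled ligand from adenosine receptor A2b (Homo sapiens), read by scintillation counting; a higher number here means a weaker inhibitor, a lower number a stronger inhibitor. Compound 1 `CCSCCn1c(=O)n(CC)c(=O)c2[nH]c(-c3ccccc3)nc21` gives 479 nM. Compound 2 `CCn1c(=O)c2c(nc(Cc3cccs3)n2C)n(Cc2ccccc2)c1=O` gives 372 nM. Compound 3 `CCn1c(=O)c2c(nc(Cc3cccs3)n2C)n(Cc2cccs2)c1=O` gives 35.5 nM, the lowest of the three numbers; its nearest neighbour is compound 2 and its furthest is compound 1, and both gaps lie beyond the scatter. Among the measured compounds shown here, the only single-point step within this set is a 10-fold lower number from compound 2 to compound 3 (1.02 log units; beyond the scatter), the swap of phenyl for thiophen-2-yl on a saturated chain carbon bound to an aromatic nitrogen.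

Compound 4 `CCn1c(=O)c2c(nc(Cc3c(F)cccc3F)n2C)n(Cc2cccs2)c1=O` has not been measured. It differs from compound 3 by 2,6-difluorophenyl in place of thiophen-2-yl on a saturated chain carbon bound to an aromatic carbon; viewed one bond further out, the change reads (thiophen-2-yl)methyl to 2,6-difluorobenzyl. For the measured compounds named here, no measured step concerns this place on the shared core: the step from compound 2 to compound 3 sits on the saturated chain carbon bound to an aromatic nitrogen and is only a loose guide. That step was large and favoured thiophen-2-yl over phenyl, so a six-membered ring of carbon only entering here is taken as more likely to raise the number than to lower it, though a shift within the scatter remains possible. The expected step is a 2.3-fold higher number from compound 3 to compound 4 (0.35 log units; beyond the scatter). Compound 4 is estimated at 80 nM, with a range from 25 nM to 300 nM in this assay.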

Compound 4, inhibition constant: 135 nM
Compound 4: the middle estimate sits 1.7-fold (0.23 log units) below what was measured; measured number inside the range.
By their numbers in this assay, from the lowest: compound 3; then compound 4; then compounds 2 and 1 (each within the scatter of the next).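

Thiophen-2-yl on the saturated chain carbon bound to an aromatic carbon, a place the earlier compounds did not vary, cannot be exchanged without cost in this assay: 2,6-difluorophenyl gives a 3.8-fold higher number from compound 3 to compound 4 (0.58 log units; beyond the scatter). This modest step shows that the place responds to its substituent, yet compound 4 still keeps a number of 135 nM, so a six-membered aromatic ring of carbon only, bearing two fluorines, is accepted here. Thiophen-2-yl now gives the lower number in both single-place comparisons, the other being a 10-fold lower number from compound 2 to compound 3 (1.02 log units; beyond the scatter) on the saturated chain carbon bound to an aromatic nitrogen, although no measurement shown accounts for either step.

The change to compound 4 alters the ring and adds fluorine at once, so the share of each remains unresolved, and an unsubstituted phenyl at this place would be needed to separate them. Also open, from the compounds shown here alone, is how this place would respond to a pyridine ring, a thiophen-3-yl group or a phenyl ring carrying a methoxy group, and whether thiophen-2-yl remains preferred against these.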